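The source may report more compounds than this note shows. Statements on the series, on what has been measured and on what is new or still open speak of the compounds shown alone.

Compound 3 `COc1ccc(C(=O)NC(CC(=O)O)c2ccc(Cl)cc2Cl)cc1` sits at the edge of what can be read in a functional assay on MDA-MB-231 cells (Homo sapiens) for antiproliferative activity, read by MTT assay, with a stated time of 24 h; a lower number here means a stronger inhibitor, a higher number a weaker inhibitor. Going by these compounds, compound 3 gives > 100000 nM, which is a limit of the assay and not a number, so its true position is unknown. Compound 2 `O=C(O)CC(NC(=O)c1cccc(Br)c1)c1ccc(Cl)cc1Cl`, which carries 3-bromophenyl on the carbonyl carbon in place of 4-methoxyphenyl, gives 82500 nM. Among the measured compounds shown here, the step between these two is an at least 1.2-fold higher number from compound 2 to compound 3 (0.08 log units; that floor lies within the scatter), and it is the only measured step at this place.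

Compound 4 `O=C(O)CC(NC(=O)c1c(Cl)cccc1Cl)c1ccc(Cl)cc1Cl` changes the same place, and its difference from compound 3 is 2,6-dichlorophenyl in place of 4-methoxyphenyl on a carbonyl carbon. The incoming 2,6-dichlorophenyl also stands on the carbonyl carbon of compound 1 `O=C(O)CC(NC(=O)c1c(Cl)cccc1Cl)c1ccccc1`, though the rest of that structure is not the same. Compound 1 is likewise reported only as a limit, > 100000 nM.

The measured evidence therefore offers no change beyond the scatter at this place, and the series stays close to the limit of > 100000 nM in this assay, at which 2 of the 3 values shown sit. No step beyond the scatter is expected in this assay, and the estimated change is an at least 1.1-fold lower number from compound 3 to compound 4 (0.04 log units; that floor lies within the scatter). Compound 4 is expected to give about 90000 nM, with an estimated range from 45000 nM to 160000 nM, and it may well be reported only as a limit.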

Compound 4, half-maximal inhibitory concentration: > 100000 nM
Compound 4: no number, only a limit; the forecaster's own chance of this, stated with the estimate: 60%; middle value at least 1.1-fold (0.04 log units) away from the limit.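

In this assay compound 4 gives > 100000 nM, which is a limit of the assay and not a number. Among the compounds shown here, compound 2 is the only partner with a number, and the change reads as an at least 1.2-fold higher number from compound 2 to compound 4 (0.08 log units; that floor lies within the scatter), so 2,6-dichlorophenyl on the carbonyl carbon brings no step beyond the scatter, while the steps to compound 4 from compound 3 and from compound 1 cannot be read, since both ends of each are limits. With 2,6-dichlorophenyl now shown alongside 2,4-dichlorophenyl on the saturated chain carbon, this place still yields no readable gain, and the series stays where it was: the limit of > 100000 nM in this assay, at which 3 of the 4 values shown sit.

Going by these compounds, how far compound 1, compound 3 and compound 4 lie past their limits remains unknown, so no order can be given among them. Also open is whether an aminophenyl group on the carbonyl carbon, in place of the groups shown, would give a value clear of the limit in this assay.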